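The source may report more compounds than this note shows. Statements on the series, on what has been measured and on what is new or still open speak of the compounds shown alone.

Measured compounds:
compound 1 `COc1cc(C(=O)c2sc(-c3ccc(C(F)(F)F)cc3)cc2N)cc(OC)c1OC`, 270 nM
compound 2 `COc1cc(C(=O)c2sc(-c3ccccc3Cl)cc2N)cc(OC)c1OC`, 16 nM

In a functional assay on CCRF-CEM cells (Homo sapiens) for antiproliferative activity (on this read-out higher numbers stand for weaker inhibition and lower numbers for stronger inhibition), compound 1 gives 270 nM, the highest of the two numbers; the nearest is compound 2, which gives 16 nM. For the measured compounds named here, the only measured step, a 17-fold lower number from compound 1 to compound 2 (1.23 log units; beyond the scatter), exchanges the whole aryl group for another. Compound 3 `COc1cc(C(=O)c2sc(-c3ccc(-c4ccccc4)cc3)cc2N)cc(OC)c1OC` differs from compound 1 by phenyl in place of trifluoromethyl on an aromatic carbon. Going by the values given here, no measured step bears on this change, since the one measured step alters the aryl group at a different point and offers no guide. For compound 3 the expected step is a 1.4-fold lower number from compound 1 to compound 3 (0.13 log units; within the scatter), with wide uncertainty. Compound 3 is estimated at 200 nM, range 40 nM to 1000 nM.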

Compound 3, half-maximal inhibitory concentration: > 10000 nM
Compound 3 gave a limit, no number; the forecaster's own chance of this, stated with the estimate: 5%; middle value at least 50-fold (1.69 log units) away from the limit.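

In this assay, for the compounds shown here, phenyl para to a large group, entering for trifluoromethyl, gives an at least 37-fold higher number from compound 1 to compound 3 (1.56 log units; beyond the scatter); the earlier compounds showed only an exchange of the whole aryl group, while this step shows that a single group at this place can decide between measurable activity and none within range. The result for compound 3 is a limit of the assay and not a number: the limit of > 10000 nM in this assay, at which 1 of the 3 values shown sits.

Still open, on these data alone, is whether the step follows the ring itself or the heavy-atom count. A methoxy group or an amine at this place would help separate the two.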